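The source may hold more compounds than are shown below. What is called first, only, known or untested is meant among the compounds shown, and "the series" means these compounds.

Measured compounds:
- compound 1 `Cc1cc(C)c2c(c1)CN(c1ccc3c(=O)cc(-c4ccccc4)oc3c1)CO2`: 11.3%
- compound 2 `O=c1cc(-c2ccccc2)oc2cc(N3COc4c(cccc4[N+](=O)[O-])C3)ccc12`: "not active" (no number reported)
- compound 3 `O=c1cc(-c2ccccc2)oc2ccc(N3COc4ccccc4C3)cc12`: 8.7%

All three share a core built from the same flavone-like unit joined to a saturated ring, and all were tested in a functional assay on MCF7 cells (Homo sapiens) for inhibition, read by MTT assay, with a stated time of 48 h, tested at 7.5 ug/mL; a lower number here means less inhibition of growth, a higher number more inhibition of growth at the concentration tested. Compound 1 gives 11.3% and compound 3 gives 8.7%; the two values lie within the usual scatter of each other, so nothing separates them. For compound 2 the outcome in this assay was reported only as "not active" (no number reported), without a number, so compound 2 stands at the bottom of what is shown, with no figure to compare against the others.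

Compound 4 `O=c1cc(-c2ccccc2)oc2cc(N3COc4c(Br)cccc4C3)ccc12` has not yet been measured. It differs from compound 2 in one place: bromo in place of nitro on an aromatic carbon. Within the data shown here, no measured pair here shows what such an exchange does, so the size of the step in this assay cannot be read from the data. Given that compound 1 and compound 3, with other substituents on the same ring, stay low, and that compound 2 gave no measurable inhibition, only a small degree of inhibition is expected for compound 4, in the region of 10%, with a range from 0% to 25%.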

Compound 4, percent growth inhibition at one concentration: 2.21%
For compound 4 the middle estimate is 7.8 percentage points above the measured one; the range from low to high includes it.
By their numbers in this assay, from the lowest: compounds 4, 3 and 1 (each within the scatter of the next).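

In this assay no step can be read from compound 2 to compound 4: compound 2 carries only the words "not active", with no number to set against compound 4. Nothing measured here explains the low values. The compounds shown leave open whether any substituent on this ring gives clearly stronger growth inhibition.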